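This account rests on a few compounds, and the source may have more. Where it says the series, first, only, none or still open, it means among the compounds named here.

Going by the values given here, compound 2 `N#Cc1ccc(SC2CCCC2)cc1C#N` is one of two compounds measured in an assay on microsomes for inhibition of Amine oxidase [flavin-containing] B (Homo sapiens), read by fluorescence and spectrophotometry, with a stated time of 20 min; on this read-out lower numbers stand for stronger inhibition and higher numbers for weaker inhibition; in that assay compound 2 gives 887 nM, the higher of the two numbers. The other, compound 1 `N#Cc1ccc(SCCc2ccccc2)cc1C#N`, carries a phenethyl group on the sulfur instead of the cyclopentyl ring, and in this assay compound 1 gives 124 nM, which lies well below the number for compound 2 and outside the usual scatter.

Compound 3 `CC(C)CCSc1ccc(C#N)c(C#N)c1` has not yet been measured. Compared with compound 2 it differs in one place: isopentyl in place of cyclopentyl on a sulfur. The ring is opened into a branched chain of the same count of carbon atoms, with the sulfur attached to the same aromatic carbon.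

Among the compounds with values here, for compound 3 the expectation is a modest lowering of the number, a step of a 1.8-fold lower number from compound 2 to compound 3 (0.25 log units; within the scatter) that could still fall within the scatter, since no measured pair here separates a ring from an open chain of equal size. Compound 3 is therefore estimated at 500 nM, with a plausible range from 150 nM to 1800 nM.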

Compound 3, half-maximal inhibitory concentration: 242 nM
For compound 3 the middle estimate is 2.1-fold (0.32 log units) above the measured one, within the range that was stated.
By their numbers in this assay, from the lowest: compounds 1 and 3 (each within the scatter of the next); then compound 2.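

In this assay, opening the cyclopentyl ring into isopentyl on the sulfur, with the count of carbon atoms unchanged, gives a 3.7-fold lower number from compound 2 to compound 3 (0.56 log units; beyond the scatter), so at this position the shape of the group matters and not only its size. Putting isopropyl in place of phenyl on a saturated chain carbon, two bonds along the chain from a sulfur, gives a 2.0-fold higher number from compound 1 to compound 3 (0.29 log units; within the scatter), which lies within the scatter, so among these compounds a phenyl ring at the end of the chain is not needed for a number in this range. Nothing here gives a measured reason for either result.

From the compounds shown here alone, whether an unbranched pentyl chain would match isopentyl, and so whether the branch itself counts, remains open. A single ring-to-chain pair also cannot show whether a cyclohexyl ring or a chain ending in an amine would follow the same trend.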